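Moving the amide closer to the core: compound 1 to compound 3

The source may hold more compounds than are shown below. What is called first, only, known or untested is meant among the compounds shown, and "the series" means these compounds.

For the measured compounds named here, compound 1 `NC(=O)CCCCc1c[nH]c2ccc(F)cc12` carries the only measured number here. In an assay on isolated protein for inhibition of Myeloperoxidase (Homo sapiens), read by ELISA, with a stated time of 5 min (a lower number here means a stronger inhibitor, a higher number a weaker inhibitor), compound 1 gives 43 nM. Compound 2 `N#CCCCc1c[nH]c2ccc(C(=O)O)cc12` is reported in this assay as "not active" (no number reported), without a number. Compound 3 `CCNC(=O)CCCc1c[nH]c2ccc(F)cc12` has not been measured; it differs from compound 1 in one place: ethylcarbamoyl in place of carbamoylmethyl on a saturated chain carbon, three bonds along the chain from an aromatic carbon. Going by the values given here, no measured pair shows this change, so the direction rests on expectation alone. The expected step of a 2.6-fold higher number from compound 1 to compound 3 (0.41 log units; beyond the scatter) is a modest weakening, slightly beyond the scatter. Compound 3 is therefore expected to give 110 nM, with a range from 25 nM to 500 nM.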

Compound 3, half-maximal inhibitory concentration: 243 nM
The estimate for compound 3 lay 2.2-fold (0.34 log units) below the measured number; low and high end bracket the measured number.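

In this assay this chain position proves sensitive: the change gives a 5.7-fold higher number from compound 1 to compound 3 (0.75 log units; beyond the scatter) and so costs strength modestly, although ethylcarbamoyl and carbamoylmethyl each count one hydrogen-bond donor and one hydrogen-bond acceptor. Those matching counts therefore do not preserve the number. Nothing available here accounts for the loss.

The compounds shown do not separate the two parts of this change, the added ethyl and the shifted amide. On these data alone, how an amine in place of the amide would read at this position also stays open.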